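Amide aryl replacement on the shared core

The source may report more compounds than this note shows. Statements on the series, on what has been measured and on what is new or still open speak of the compounds shown alone.

Among the compounds with values here, compound 1 `Cc1ccc(NC(=O)COc2ccc3cc(/C=C4/SC(=O)NC4=O)ccc3c2)cc1` gives 1700 nM in an assay on isolated protein for inhibition of histone deacetylase 4 (Homo sapiens), with a stated time of 1 h (a lower number here means a stronger inhibitor, a higher number a weaker inhibitor), the second highest of the three numbers so far. Nearest to it is compound 2 `O=C(COc1ccc2cc(/C=C3/SC(=O)NC3=O)ccc2c1)Nc1ccc(F)cc1F` at 3900 nM; compound 3 `Cc1cc(Br)ccc1NC(=O)COc1ccc2cc(/C=C3/SC(=O)NC3=O)ccc2c1` stands furthest, at 550 nM. Compound 4 `Cc1cc(NC(=O)COc2ccc3cc(/C=C4/SC(=O)NC4=O)ccc3c2)no1` differs from compound 1 in one place: 5-methyl-1,2-oxazol-3-yl in place of 4-methylphenyl on an amide-type nitrogen. Within the data shown here, two measured steps bear on it, both altering the group on the amide-type nitrogen: a 2.3-fold higher number from compound 1 to compound 2 (0.36 log units; beyond the scatter) and a 3.1-fold lower number from compound 1 to compound 3 (0.49 log units; beyond the scatter). Among the measured compounds shown here, neither involves a five-membered heteroaryl ring, so the new group has no close precedent here; the measured steps show only that changes at this position shift the number modestly in either direction. For compound 4 a modest weakening is expected, a 1.6-fold higher number from compound 1 to compound 4 (0.22 log units; within the scatter). Compound 4 is therefore estimated at 2800 nM, with a range from 900 nM to 8000 nM.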

Compound 4, half-maximal inhibitory concentration: 1700 nM
Compound 4: middle estimate off by 1.6-fold (0.22 log units), on the high side, within the range that was stated.
By their numbers in this assay, from the lowest: compound 3; then compounds 1 and 4 (each within the scatter of the next); then compound 2.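

The 5-methyl-1,2-oxazol-3-yl group, a five-membered aromatic ring with 2 hetero atoms, can replace 4-methylphenyl on the amide-type nitrogen in this assay without a measurable loss (no change at the digits printed from compound 1 to compound 4 (within the scatter)), so a six-membered aromatic ring of carbon only is not required at this position. The group also keeps compound 4 inside the span set by the aryl amides (a 3.1-fold higher number from compound 3 to compound 4 (0.49 log units; beyond the scatter); a 2.3-fold lower number from compound 2 to compound 4 (0.36 log units; beyond the scatter)). No supporting data explain this result.

As far as these compounds go, whether the methyl on the 1,2-oxazole ring contributes remains open. So does the effect of a bromo group on that ring, or of a saturated amine such as piperidine.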